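Swapping a Methyl for a Hydroxy on Compound 1

This account rests on a few compounds, and the source may have more. Where it says the series, first, only, none or still open, it means among the compounds named here.

In a functional assay on DWD cells (Homo sapiens) for inhibition, read by sulforhodamine B assay (a lower number here means a stronger inhibitor of growth, a higher number a weaker inhibitor of growth), compound 1 `Cc1ccc2[nH]c(-c3ccc(-c4ccc(-c5ccc(N(C)C)cc5)cc4)cc3)nc2c1` gives 3230 nM. Compound 2 `COc1ccc(-c2ccc(-c3ccc(-c4nc5cc(C)ccc5[nH]4)cc3)cc2)cc1OC` gives 1720 nM, and the measured step is a 1.9-fold lower number from compound 1 to compound 2 (0.27 log units; within the scatter), so these two cannot be told apart. Compound 3 `COc1ccc(-c2ccc(-c3ccc(-c4nc5ccccc5[nH]4)cc3)cc2)cc1OC` sits clearly higher, at 42100 nM.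

Compound 4 `CN(C)c1ccc(-c2ccc(-c3ccc(-c4nc5c(O)cccc5[nH]4)cc3)cc2)cc1` has not yet been measured. It carries 4-hydroxy-1H-benzimidazol-2-yl in place of the 5-methyl-1H-benzimidazol-2-yl of compound 1: 4-hydroxy-1H-benzimidazol-2-yl in place of 5-methyl-1H-benzimidazol-2-yl on an aromatic carbon.

The step to compound 2 changes a different group, the 4-(dimethylamino)phenyl that compound 4 keeps, so it says little about this swap. The most relevant evidence is a 24-fold higher number from compound 2 to compound 3 (1.39 log units; beyond the scatter), a large loss of growth inhibition when the methyl gives way to hydrogen. Compound 4 also loses that methyl, so a higher number is expected. However, that step was measured with 3,4-dimethoxyphenyl in the molecule, and no measured compound carries the hydroxy, so its contribution is unknown. The expected change is therefore smaller and less certain, with an estimated 3.7-fold higher number from compound 1 to compound 4 (0.57 log units; beyond the scatter). For compound 4 the estimated value is 12000 nM, with an expected range of 2500 nM to 50000 nM.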

Compound 4, concentration for 50% growth inhibition: 9210 nM
Estimate against measurement, compound 4: 1.3-fold (0.11 log units) above; the range from low to high includes it.
By their numbers in this assay, from the lowest: compounds 2 and 1 (each within the scatter of the next); then compound 4; then compound 3.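

In this assay, replacing 5-methyl-1H-benzimidazol-2-yl with 4-hydroxy-1H-benzimidazol-2-yl gives a 2.9-fold higher number from compound 1 to compound 4 (0.46 log units; beyond the scatter), so this change costs a modest but real amount of growth inhibition when the 4-(dimethylamino)phenyl group stays in place. For the compounds shown here, the earlier compounds showed only the loss of the methyl, as a 24-fold higher number from compound 2 to compound 3 (1.39 log units; beyond the scatter), and that large step was measured with 3,4-dimethoxyphenyl at the far end of the molecule, so the new step is the first reading of a hydroxy-bearing benzimidazole and the first change to this part of the molecule with 4-(dimethylamino)phenyl present. Nothing here gives a measured reason for the loss in growth inhibition.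

The compounds shown leave open how much of the step comes from losing the methyl and how much from adding the hydroxy, and the group's place also differs between the two names. A matching compound with hydrogen in place of the methyl and 4-(dimethylamino)phenyl kept would separate these contributions, and a methoxy or an amine at the hydroxy's place would show how much that group itself matters.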